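The source may report more compounds than this note shows. Statements on the series, on what has been measured and on what is new or still open speak of the compounds shown alone.

In a functional assay on MCF7 cells (Homo sapiens) for inhibition, read by MTT assay, with a stated time of 72 h (on this read-out higher numbers stand for weaker inhibition and lower numbers for stronger inhibition), two compounds have been measured
- compound 1 `CCC(=O)[C@@H](C)c1oc([C@H](C)[C@@H]2O[C@](O)([C@@H](C)c3oc(CC)c(C)c(=O)c3C)[C@@H](C)[C@@H](O)[C@@H]2C)c(C)c(=O)c1C` gives 87000 nM
- compound 2 `CCC(=O)[C@H](C)c1oc([C@H](C)[C@@H]2O[C@](O)([C@@H](C)c3oc(CC)c(C)c(=O)c3C)[C@@H](C)[C@@H](O)[C@@H]2C)c(C)c(=O)c1C` gives > 100000 nM (a limit)

Compound 2 stands at > 100000 nM, which is a limit of the assay and not a number. Compound 3 `CCC(=O)[C@H](C)c1oc([C@H](C)[C@@H]2O[C@](O)([C@@H](C)c3oc(CC)c(C)c(=O)c3C)[C@@H](C)[C@@H](OC(=O)CC(C)C)[C@@H]2C)c(C)c(=O)c1C` carries one change from it, (isobutylcarbonyl in place of hydrogen on an oxygen on a saturated carbon), with hydroxy going to (isobutylcarbonyl)oxy. For the measured compounds named here, the only measured step, an at least 1.1-fold higher number from compound 1 to compound 2 (0.06 log units; that floor lies within the scatter), is a difference in configuration alone (the fact that compounds 1 and 2 differ only in the configuration as drawn), so it gives no measure for this change. No step beyond the scatter is therefore expected in this assay, in either direction. The expected step is an at least 1.1-fold lower number from compound 2 to compound 3 (0.04 log units; that floor lies within the scatter). Compound 3 is estimated at 90000 nM, with an expected range of 25000 nM to 200000 nM.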

Compound 3, half-maximal inhibitory concentration: 21000 nM
Compound 3: the middle estimate sits 4.3-fold (0.63 log units) above what was measured, and the stated range ends above it.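

In this assay, isobutylcarbonyl in place of hydrogen on this oxygen gives an at least 4.7-fold lower number from compound 2 to compound 3 (0.67 log units; beyond the scatter), a step beyond the scatter. The earlier compounds gave no measure of any change at this position: the fact that compounds 1 and 2 differ only in the configuration as drawn Compound 2 stands at > 100000 nM, which is a limit of the assay, so the step is a floor and its full size stays unknown: the limit of > 100000 nM in this assay, at which 1 of the 3 values shown sits.

The compounds shown leave open whether an acetyl group or a longer chain on this oxygen would give a similar step, or an amine in place of the hydroxy. Also open, from the compounds shown here alone, is whether the same change on compound 1 would give a similar step.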